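A few compounds are considered here, and "the series" means these few. Any claim that something is new, unique, unknown or untested is made for them only; others in the source may bear on it.

In a functional assay on the whole organism with Mus musculus as the target, at a dose of 100 mg/kg by the intraperitoneal route (on this read-out higher numbers stand for more inhibition at the one dose given (going by the name of the read-out) and lower numbers for less inhibition), compound 1 `CCN(C)C(=O)/C=C1\CCc2c(F)cc(F)cc21` gives 100%. Compound 2 `CNC(=O)/C=C1\CCc2cc(F)c(F)cc21` gives 100%, so the two stand level at the digits shown and together hold the highest of the three numbers measured. Compound 3 `CNC(=O)/C=C1\CCc2ccc(Cl)cc21` gives 16%, a number far below compound 1 and well beyond the scatter. The step under consideration leads from compound 1 to compound 4 `CCNC(=O)/C=C1\CCc2c(F)cc(F)cc21`, which has not yet been measured in this assay. The change is hydrogen in place of methyl on an amide-type nitrogen. Within the data shown here, no pair of measured compounds tests this exact change on its own. Still, compound 2, which also carries a hydrogen on its amide-type nitrogen and sits on a closely related core, gives 100% in this assay. Compound 4 is therefore expected to stay high, and the step of a number 12 percentage points lower from compound 1 to compound 4 (beyond the scatter) is expected to be small, most likely nothing beyond the scatter. The estimate for compound 4 is 88%, with a range from 50% to 100%.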

Compound 4, a percentage reported as inhibition, in the whole organism at one dose (the size of the read-out at that dose, not a potency): 67%
For compound 4 the middle estimate is 21 percentage points above the measured one; measured number inside the range.
By their numbers in this assay, from the lowest: compound 3; then compound 4; then compounds 1 and 2 (each within the scatter of the next).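

In this assay hydrogen in place of methyl on an amide-type nitrogen whose other neighbours are a carbonyl carbon and a saturated chain carbon gives a number 33 percentage points lower from compound 1 to compound 4 (beyond the scatter) on the shared core. Among these compounds, this is the first direct reading of this position, and it shows that the methyl cannot be removed here without a clear loss at this dose, although compound 4 still gives 67% and so keeps a good part of the read-out. Nothing at hand accounts for the size of this step. On these data alone, it remains open whether a propyl group in place of the methyl would hold the number of compound 1 or lower it. As far as these compounds go, a pyrrolidine ring closed through the amide nitrogen is equally open on this core.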